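Bromo-fluoro aryl swap on a weak diketopiperazine-type pair

The source may hold more compounds than are shown below. What is called first, only, known or untested is meant among the compounds shown, and "the series" means these compounds.

Compound 1 `C=CCn1c(=O)/c(=C\c2cccc(C)c2)[nH]c(=O)/c1=C\c1ccccc1OC` is the weaker of the two compounds measured in a functional assay on BGC-823 cells (Homo sapiens) for cytotoxicity, read by CCK-8 assay, with a stated time of 72 h; a lower number here means a stronger inhibitor, a higher number a weaker inhibitor: compound 1 gives 20400 nM, the highest of the two numbers seen so far. Compound 2 `COc1ccccc1/C=c1/[nH]c(=O)/c(=C\c2nc[nH]c2C(C)(C)C)[nH]c1=O` differs from compound 1 in more than one place, so its number is noted only for orientation; in this assay compound 2 gives 90 nM, and the gap between the two values lies well beyond the scatter.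

Compound 3 `C=CCn1c(=O)/c(=C\c2cc(Br)ccc2F)[nH]c(=O)/c1=C\c1ccccc1OC` keeps the core of compound 1 and changes one group: 5-bromo-2-fluorophenyl in place of 3-methylphenyl on a double-bonded chain carbon bound to an aromatic carbon. Going by the values given here, no measured pair shows what this exchange does here, and the only other compound on hand, compound 2, is altered elsewhere as well, so it gives no direct guidance.

With nothing to anchor the direction, the step from compound 1 to compound 3 is expected to be small, likely within or just beyond the scatter, as a 1.4-fold lower number from compound 1 to compound 3 (0.13 log units; within the scatter) states. For compound 3 in this assay the expected value is 15000 nM, with a plausible range from 4000 nM to 50000 nM.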

Compound 3, half-maximal inhibitory concentration: "not active" (no number reported)
Nothing numeric was reported for compound 3, so the estimate cannot be set against anything.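

Going by these compounds alone, compound 3 is reported as "not active" in this assay without a number, so no step from compound 1 to compound 3 can be read. Nothing measured here bears on this result. The compounds shown leave open how far 5-bromo-2-fluorophenyl in place of 3-methylphenyl moves the number on the shared core.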